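This account rests on a few compounds, and the source may have more. Where it says the series, first, only, none or still open, it means among the compounds named here.

Compound 1 `CO[C@H]1O[C@@H]([C@H](N=[N+]=[N-])C(=O)OCc2ccccc2)[C@@H](OCc2ccccc2)[C@@]2(OCc3ccccc3)[C@@H](OCc3ccccc3)CO[C@@H]12` gives 47.9% in an ADME assay on A549 cells (Homo sapiens) for cytotoxicity, read by MTT assay, with a stated time of 24 h, tested at 200 ug/mL; on this read-out lower numbers stand for a stronger effect and higher numbers for a weaker effect at the one concentration tested.
Compound 2 `CC(=O)Nc1nc(Cl)c2c(ncn2[C@@H]2O[C@@H]([C@H](N=[N+]=[N-])C(=O)OCc3ccccc3)[C@@H](OCc3ccccc3)[C@@]3(OCc4ccccc4)[C@@H](OCc4ccccc4)CO[C@@H]23)n1` gives 51.3%.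
Compound 3 `COC(=O)[C@@H](N=[N+]=[N-])[C@@H]1O[C@@H](n2cnc3nc(NC(C)=O)nc(Cl)c32)[C@@H]2OC[C@H](OCc3ccccc3)[C@]2(OCc2ccccc2)[C@@H]1OCc1ccccc1` gives 19.5%.

Of these three, compound 3 stands lowest in this assay, beyond the scatter from both others; its nearest neighbour is compound 1 and its furthest is compound 2. Among the compounds with values here, the only step measured so far, a number 31.8 percentage points lower from compound 2 to compound 3 (beyond the scatter), concerns a different kind of change and does not bear on what follows. Compound 4 `COC(=O)[C@H](N=[N+]=[N-])[C@@H]1O[C@@H](n2cnc3nc(NC(C)=O)nc(Cl)c32)[C@@H]2OC[C@H](OCc3ccccc3)[C@]2(OCc2ccccc2)[C@@H]1OCc1ccccc1` is the unmeasured partner of compound 3: the two compounds have the same atoms and bonds; at least one stereo element is drawn with a configuration in one of them and without one in the other: 1 of 8 stereo elements differ; a stereocentre at a saturated chain carbon is drawn S in compound 3 and R in compound 4. Within the data shown here, no measured pair shows what such a change in drawn configuration does here, so no step beyond the scatter is expected, a number 0.5 percentage points higher from compound 3 to compound 4 (within the scatter). Compound 4 is therefore estimated at 20%, within a range from 5% to 40%.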

Compound 4, a percentage reported as activity, at one concentration (the size of the read-out at that concentration, not a potency): 52.3%
Compound 4: the middle estimate sits 32.3 percentage points below what was measured; measured number above the stated range.
By their numbers in this assay, from the lowest: compound 3; then compounds 1, 2 and 4 (each within the scatter of the next).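

In this assay, the drawn configuration at this saturated chain carbon proves to matter on its own: a number 32.8 percentage points higher from compound 3 to compound 4 (beyond the scatter), although the atoms and bonds stay the same. The low number of compound 3 is thus tied to the S configuration drawn at this one carbon. The only recorded difference within the pair is this: the fact that one of compounds 3 and 4 is drawn with a defined configuration and the other without, at the place where they differ

As far as these compounds go, whether the configuration at this carbon matters as much when an amine stands in place of the azide, or a carboxylic acid in place of the ester, remains open.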